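Swapping Isobutylamino for Ethyl(methyl)amino on a Shared Core

This account rests on a few compounds, and the source may have more. Where it says the series, first, only, none or still open, it means among the compounds named here.

Within the data shown here, only two compounds have been measured so far in a functional assay on HCT-116 cells (Homo sapiens) for antiproliferative activity, read by MTT assay, with a stated time of 72 h; a higher number here means a weaker inhibitor, a lower number a stronger inhibitor. There, compound 1 (`CC(C)CNC(=N)NC(=N)Nc1ccc(C(F)(F)F)cc1`) gives 3500 nM, the lower of the two numbers and so the stronger inhibitor. Compound 2 (`CC(C)CNC(=N)NC(=N)Nc1ccc(F)c(F)c1`) gives 29700 nM, a gap well beyond the usual scatter of repeated measurements.

Compound 3 (`CCN(C)C(=N)NC(=N)Nc1ccc(C(F)(F)F)cc1`) has not yet been measured. It keeps the core of compound 1 and differs at one place, a carbon with a double bond to nitrogen: ethyl(methyl)amino in place of isobutylamino on a carbon with a double bond to nitrogen. In short, ethyl(methyl)amino takes the place of isobutylamino.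

Among the measured compounds shown here, no pair of measured compounds shows what a change at this place does, so any forecast here is uncertain. A moderate step towards a weaker inhibitor is expected in this assay, starting from the 3500 nM of compound 1. The estimated step is a 2.9-fold higher number from compound 1 to compound 3 (0.46 log units; beyond the scatter), although a result within the scatter would not be surprising. Compound 3 is expected at about 10000 nM, with an estimated range of 3000 nM to 35000 nM.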

Compound 3, half-maximal inhibitory concentration: 4000 nM
Compound 3: the middle estimate sits 2.5-fold (0.40 log units) above what was measured; low and high end bracket the measured number.
By their numbers in this assay, from the lowest: compounds 1 and 3 (each within the scatter of the next); then compound 2.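

In this assay, putting ethyl(methyl)amino in place of isobutylamino on a carbon with a double bond to nitrogen gives a 1.1-fold higher number from compound 1 to compound 3 (0.06 log units; within the scatter). Among these compounds, this is the first direct view of this position, and it shows that, on the core of compound 1, this position accepts the swap from isobutylamino, with 5 heavy atoms and 1 hydrogen-bond donor, to ethyl(methyl)amino, with 4 heavy atoms and 0 hydrogen-bond donors, without a difference larger than repeat measurements would give. No supporting measurement is available to explain why the two groups give such similar results.

This single pair cannot show whether ethyl(methyl)amino would behave the same way on the core of compound 2, where the ring carries two fluorines instead of trifluoromethyl. It also leaves open how far this position's tolerance extends, for instance to a small group such as a plain amine, a longer chain such as hexylamino, or a charged group such as a carboxylic acid.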